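A few compounds are considered here, and "the series" means these few. Any claim that something is new, unique, unknown or untested is made for them only; others in the source may bear on it.

Measured compounds:
- compound 1, `COc1cc(-c2nnc(SCC(=O)c3ccc(Cl)cc3)n2N)cc(OC)c1OC`, 13100 nM
- compound 2, `COc1cc(-c2nnc(SCC(=O)c3ccc(F)cc3)n2N)cc(OC)c1OC`, 20900 nM

Both were tested in a functional assay on HeLa cells (Homo sapiens) for antiproliferative activity, read by MTT assay, with a stated time of 48 h; on this read-out lower numbers stand for stronger inhibition and higher numbers for weaker inhibition. Compound 2 has the higher of the two numbers, but its gap to compound 1, a 1.6-fold higher number from compound 1 to compound 2 (0.20 log units; within the scatter), is within the scatter, so the two cannot be told apart.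

Compound 3, `COc1cc(-c2nnc(SCC(=O)Nc3ccccc3)n2N)cc(OC)c1OC`, is not yet measured. It differs from compound 2 by anilino in place of 4-fluorophenyl on a carbonyl carbon; seen one bond further out, a (4-fluorophenyl)carbonyl becomes a phenylcarbamoyl. Among the compounds with values here, the only measured step, from compound 1 to compound 2, swaps one halogen for another and does not touch the carbonyl region, so no measured step bears on this change. There is therefore no basis for expecting a shift in either direction beyond the scatter, and the estimate for compound 3 is simply placed near compound 2, with a wide range, as a 1.0-fold lower number from compound 2 to compound 3 (0.02 log units; within the scatter).

Compound 3 is estimated at 20000 nM, with a range from 5000 nM to 80000 nM.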

Compound 3, half-maximal inhibitory concentration: 8280 nM
For compound 3 the middle estimate is 2.4-fold (0.38 log units) above the measured one, within the range that was stated.
By their numbers in this assay, from the lowest: compounds 3, 1 and 2 (each within the scatter of the next, the first and the last beyond it).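

Within the data shown here, at this carbonyl carbon, anilino in place of 4-fluorophenyl gives a 2.5-fold lower number from compound 2 to compound 3 (0.40 log units; beyond the scatter) in this assay and is the first step in this small set to pass beyond the scatter, though only modestly. Anilino in place of 4-chlorophenyl gives a 1.6-fold lower number from compound 1 to compound 3 (0.20 log units; within the scatter) and so leaves compound 1 and compound 3 indistinguishable, which means the shift is seen against the fluoro compound alone. The swap puts a nitrogen link and the amide hydrogen in place and removes the halogen all at once, and nothing available here explains the shift.

Still open, as far as these compounds go, is which of these parts matters. A 4-fluoroanilino group would keep the halogen along with the nitrogen link, while an N-methylanilino group would lack the amide hydrogen.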